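Methoxy to Bromo: One Change Seen Twice

The source may report more compounds than this note shows. Statements on the series, on what has been measured and on what is new or still open speak of the compounds shown alone.

Compound 1 `COc1ccc(-c2cc3ccc(OCCCn4cc(CNC(=O)CCCCC5CCSS5)nn4)cc3oc2=O)cc1` and compound 2 `O=C(CCCCC1CCSS1)NCc1cn(CCCOc2ccc3cc(-c4ccc(Br)cc4)c(=O)oc3c2)nn1` share a core and differ in one place: bromo in place of methoxy on an aromatic carbon. In a functional assay on PC-12 cells (Rattus norvegicus) for cytotoxicity, read by MTT assay, with stated times of 3 h and 2 h, tested at 5 uM (on this read-out higher numbers stand for a stronger effect at the one concentration tested and lower numbers for a weaker effect), compound 1 gives 52.8%, and compound 2 gives 57.3%, so the step is a number 4.5 percentage points higher from compound 1 to compound 2 (within the scatter).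

Compound 3 `COc1ccc(-c2cc3ccc(OCCCCn4cc(CNC(=O)CCCCC5CCSS5)nn4)cc3oc2=O)cc1` carries the methoxy group on a core that is not the same as that of compound 1; the difference between the two cores is not broken down here. In this assay compound 3 gives 44.9%. Its value and that of compound 1 lie within the scatter of each other, while the gap to compound 2 lies beyond it.

Compound 4 `O=C(CCCCC1CCSS1)NCc1cn(CCCCOc2ccc3cc(-c4ccc(Br)cc4)c(=O)oc3c2)nn1` stands to compound 3 as compound 2 stands to compound 1, with the same change at the same place: bromo in place of methoxy on an aromatic carbon. Since this change once gave a number 4.5 percentage points higher from compound 1 to compound 2 (within the scatter), a step of about the same size is expected again. For compound 4 the expected step is therefore a number 4.1 percentage points higher from compound 3 to compound 4 (within the scatter), a step that stays within the scatter. Compound 4 is estimated to give 49% in this assay, with a likely range from 38% to 60%.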

Compound 4, a percentage reported as activity, at one concentration (the size of the read-out at that concentration, not a potency): 40.5%
For compound 4 the middle estimate is 8.5 percentage points above the measured one; measured number inside the range.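

In this assay, putting bromo in place of methoxy on the core of compound 3 gives a number 4.4 percentage points lower from compound 3 to compound 4 (within the scatter). Set beside the earlier case, the two steps do not differ by more than repeated measurements of this kind would: the same change on two cores in this assay, a number 4.5 percentage points higher (within the scatter) from compound 1 to compound 2 and a number 4.4 percentage points lower (within the scatter) from compound 3 to compound 4, 8.9 percentage points apart, within the scatter of two such steps. On these two cores, then, the swap from 4-methoxyphenyl to 4-bromophenyl leaves the reading within the usual scatter each time, so the change carries across as a step too small to tell from noise, but these two pairs show neither a real effect in either direction nor how the change would behave on any other core.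

Still open, going by these compounds, is whether a different group at that spot on the aromatic ring, such as an amine or a carboxylic acid, would move the number beyond the scatter. Also open, on these data alone, is what a longer chain would do at the place where the cores of compound 1 and compound 3 differ, and how these compounds would compare at other concentrations.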